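Compound 2 to compound 4: ester in place of aryl

This account rests on a few compounds, and the source may have more. Where it says the series, first, only, none or still open, it means among the compounds named here.

In a functional assay on HL-60 cells (Homo sapiens), with a stated time of 4 days (on this read-out higher numbers stand for weaker inhibition and lower numbers for stronger inhibition), compound 2 `O=C(Nc1ccc(Cl)c(Cl)c1)c1nc[nH]c1C(=O)NCc1ccc(Cl)cc1` gives 8800 nM. This lies within the scatter of compound 1 `O=C(NC1CCCCC1)c1nc[nH]c1C(=O)Nc1ccc(Cl)c(Cl)c1`, which gives 12300 nM. Compound 3 `O=C(NCc1ccc(-c2ccccc2)cc1)c1nc[nH]c1C(=O)Nc1ccc(Cl)c(Cl)c1` gives 2900 nM, a lower number than compound 2 by more than the scatter.

Compound 4 `CC(C)(C)OC(=O)CNC(=O)c1[nH]cnc1C(=O)Nc1ccc(Cl)c(Cl)c1` has not yet been measured. The change from compound 2 to compound 4 is tert-butoxycarbonyl in place of 4-chlorophenyl on a saturated chain carbon bound to an amide-type nitrogen. Going by the values given here, no two measured compounds differ in one place only, and none carries this group, so the guidance is thin. The nearest reference is compound 1, which also has no aromatic ring in that amide substituent and gives 12300 nM. The expected step, a 1.6-fold higher number from compound 2 to compound 4 (0.20 log units; within the scatter), stays within the scatter, with a slight lean to a higher number in this assay. Compound 4 is estimated at 14000 nM, with an expected range of 6000 nM to 35000 nM.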

Compound 4, half-maximal inhibitory concentration: 25400 nM
Estimate against measurement, compound 4: 1.8-fold (0.26 log units) below; low and high end bracket the measured number.
By their numbers in this assay, from the lowest: compound 3; then compounds 2 and 1 (each within the scatter of the next); then compound 4.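

In this assay this amide substituent proves sensitive to the exchange: the result is a 2.9-fold higher number from compound 2 to compound 4 (0.46 log units; beyond the scatter) when tert-butoxycarbonyl takes the place of 4-chlorophenyl on a saturated chain carbon bound to an amide-type nitrogen. Going by these compounds alone, this pair is the first to differ in one place only, and so gives the first direct reading of this position, with a step beyond the scatter. The heavy-atom count stays the same while the aromatic ring leaves and two hydrogen-bond acceptors enter, and no measurement here bears on what underlies the step.

As far as these compounds go, whether the step follows from the loss of the aromatic ring or from the presence of the ester remains open. A carboxylic acid, a primary amide or a simple alkyl chain at this place would help to separate those two readings.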